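Replacing the hydroxy group of compound 3 with hydrogen

The source may report more compounds than this note shows. Statements on the series, on what has been measured and on what is new or still open speak of the compounds shown alone.

In an ADME assay on HEp-2 cells (Homo sapiens) for cytotoxicity, read by MTT assay, with a stated time of 72 h (on this read-out lower numbers stand for stronger inhibition and higher numbers for weaker inhibition), the three measured compounds all return limits, and none returns a number. Compound 3 (`COc1ccc(C2=C(c3cc(OC)c(OC)c(OC)c3)C(=O)CC2O)cc1O`) gives < 1 ug/mL as a limit of the assay. Compound 1 (`COc1ccc(C2=C(c3cc(OC)c(OC)c(OC)c3)CC(O)C2=O)cc1[N+](=O)[O-]`) gives > 100 ug/mL as a limit of the assay. Compound 2 (`COC(=O)c1cc(C2=C(c3cc(OC)c(OC)c(OC)c3)C(=O)CC2O[SiH2]C(C)(C)C)ccc1OC`) gives > 100 ug/mL as a limit of the assay. Compound 3 therefore stands alone at the limit of < 1 ug/mL in this assay, at which 1 of the 3 values shown sits, and the other two share the limit of > 100 ug/mL in this assay, at which 2 of the 3 values shown sit, on this scale.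

Compound 4 (`COc1ccc(C2=C(c3cc(OC)c(OC)c(OC)c3)C(=O)CC2O)cc1`) differs from compound 3 by hydrogen in place of hydroxy on an aromatic carbon, so 3-hydroxy-4-methoxyphenyl becomes 4-methoxyphenyl. Among the measured compounds shown here, no measured pair differs in one place, so the size of this change remains unmeasured in this assay for now. For the measured compounds named here, compound 3 is the only measured compound carrying 3-hydroxy-4-methoxyphenyl, so weaker inhibition is the expected direction. The expected step, beyond the scatter, is an at least 5.0-fold higher number from compound 3 to compound 4 (0.69 log units; beyond the scatter) as a rough estimate from a limit. Compound 4 is estimated at 5 ug/mL with an expected range of 0.5 ug/mL to 60 ug/mL in this assay for the coming measurement.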

Compound 4, half-maximal inhibitory concentration: > 100 ug/mL
Compound 4: no number, only a limit; the forecaster's own chance of this, stated with the estimate: 35%; middle value at least 20-fold (1.30 log units) from the limit.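

In this assay, among the compounds shown here, hydrogen in place of hydroxy on an aromatic carbon, the change from 3-hydroxy-4-methoxyphenyl to 4-methoxyphenyl, gives an at least 100-fold higher number from compound 3 to compound 4 (2.00 log units; beyond the scatter); this is the first comparison that differs in one place. For the compounds shown here, the hydroxy group, ortho to a methoxy group and meta to a large group, therefore separates the two ends of the measured scale for this pair, something the earlier compounds could not show. Compound 4 ends at a limit and not at a number: the limit of > 100 ug/mL in this assay, at which 3 of the 4 values shown sit.

As far as these compounds go, both ends of the step are limits, so the full size of the change and the actual value of either compound remain open. Also open, from the compounds shown here alone, is whether an amino group or a fluorine at this position would keep compound 4 at its limit or move it towards compound 3.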